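From 1,3-benzoxazol-5-yl to 1H-indazol-5-yl: what to expect

A few compounds are considered here, and "the series" means these few. Any claim that something is new, unique, unknown or untested is made for them only; others in the source may bear on it.

Going by the values given here, only two compounds have numbers so far in an ADME assay (liver) for metabolic stability, with Liver microsome (Rattus norvegicus) as the target, using microsomes and NADPH, with a stated time of 30 min, tested at 1 uM; on this read-out higher numbers stand for fast clearance and lower numbers for slow clearance. Compound 1 `Nc1ccc(S(=O)(=O)N2CCN(c3ncc(C(O)(C(F)(F)F)C(F)(F)F)cc3C#CCCO)CC2)cn1` gives 68 mL.min-1.g-1, and compound 2 `Nc1ccc(S(=O)(=O)N2CCN(c3ncc(C(O)(C(F)(F)F)C(F)(F)F)cc3-c3ccc4ocnc4c3)CC2)cn1` gives 120 mL.min-1.g-1. These two values lie within the usual scatter of each other, so repeat measurements alone could account for the gap, and compound 2 cannot be told apart from compound 1.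

Compound 3 `Nc1ccc(S(=O)(=O)N2CCN(c3ncc(C(O)(C(F)(F)F)C(F)(F)F)cc3-c3ccc4[nH]ncc4c3)CC2)cn1` keeps the shared core of compound 2 and exchanges one group: 1H-indazol-5-yl in place of 1,3-benzoxazol-5-yl on an aromatic carbon. Both groups are built from a five-membered aromatic ring with 2 hetero atoms and a six-membered aromatic ring of carbon only.

Among the compounds with values here, one measured step bears on this aromatic carbon: a 1.8-fold higher number from compound 1 to compound 2 (0.25 log units; within the scatter), with 1,3-benzoxazol-5-yl in place of 4-hydroxybut-1-yn-1-yl. Within the data shown here, no measured compound yet carries 1H-indazol-5-yl. Among the measured compounds shown here, with a 1.8-fold higher number from compound 1 to compound 2 (0.25 log units; within the scatter) as the only guide, no step beyond the scatter is expected in this assay. The expected size is a 1.2-fold lower number from compound 2 to compound 3 (0.08 log units; within the scatter), which stays within the scatter. For compound 3 the estimated value is 100 mL.min-1.g-1, with an expected range from 45 mL.min-1.g-1 to 220 mL.min-1.g-1.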

Compound 3, intrinsic clearance in microsomes: 88 mL.min-1.g-1
Beside the measured number, compound 3's estimate is 1.1-fold (0.06 log units) above it; measured number inside the range.
By their numbers in this assay, from the lowest: compounds 1, 3 and 2 (each within the scatter of the next).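

Exchanging 1,3-benzoxazol-5-yl for 1H-indazol-5-yl on this aromatic carbon keeps the ring types and swaps a ring oxygen for a ring nitrogen that carries a hydrogen-bond donor, and in this assay this gives a 1.4-fold lower number from compound 2 to compound 3 (0.13 log units; within the scatter). The comparison with the open chain, 4-hydroxybut-1-yn-1-yl, gives a 1.3-fold higher number from compound 1 to compound 3 (0.11 log units; within the scatter), so all three compounds now lie within the scatter of one another, and neither fused ring system can be separated from the chain on this read-out. Nothing measured here explains why these groups give such similar clearance numbers.

The compounds shown leave open whether any group at this position, such as a carboxylic acid, a simple amine or a longer chain ending in an amine, would produce a step beyond the scatter in this assay. Since all three compounds share the same remaining structure, they also say nothing about how changes elsewhere on the shared core, for example to the 2,2,2-trifluoro-1-hydroxy-1-(trifluoromethyl)ethyl group, would affect clearance.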